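Piperazine substituent change in a cytotoxicity series

The compounds below may be only part of what the source reports. "The series", "measured", "known", "first", "only" and "open" are said of these compounds alone.

Compound 1, `Cn1c(-c2ccc(NC(=O)CSc3nc4ccccc4o3)cc2)nc(-c2ccccc2)c1-c1ccccc1`, gives 44.9% in a functional assay on HT-29 cells (Homo sapiens) for cytotoxicity, read by MTT assay, with a stated time of 24 h, tested at 6.4 ug/mL; on this read-out lower numbers stand for a weaker effect and higher numbers for a stronger effect at the one concentration tested.
Compound 2, `Cn1ccnc1SCC(=O)Nc1ccc(-c2nc(-c3ccccc3)c(-c3ccccc3)n2C)cc1`, gives 30.7% in this assay.
Compound 3, `CCN1CCN(CC(=O)Nc2ccc(-c3nc(-c4ccccc4)c(-c4ccccc4)n3C)cc2)CC1`, gives 17.2% in this assay.

Compound 3 stands lowest of the three in this assay, beyond the scatter from both others: the step of a number 27.7 percentage points lower from compound 1 to compound 3 (beyond the scatter) and the step of a number 13.5 percentage points lower from compound 2 to compound 3 (beyond the scatter) both run downward to it. The two aromatic sulfanyl analogues also differ from each other, with a number 14.2 percentage points lower from compound 1 to compound 2 (beyond the scatter).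

Compound 4, `Cn1c(-c2ccc(NC(=O)CN3CCN(Cc4ccc(Cl)cc4)CC3)cc2)nc(-c2ccccc2)c1-c1ccccc1`, has not been measured. It differs from compound 3 by 4-chlorophenyl in place of methyl on a saturated chain carbon bound to an amine nitrogen in a ring. Among the compounds with values here, none of the measured steps touches this part of the molecule: all three concern the replacement of the whole group on the chain carbon bound to the carbonyl carbon, whereas compound 4 keeps the 4-ethylpiperazin-1-yl framework and alters only the substituent on its amine nitrogen. The measured steps therefore give no direct guide, and the expectation rests on compound 3 alone.

Compound 4 is estimated at 24%, within 8% to 45%. The expected step is a number 6.8 percentage points higher from compound 3 to compound 4 (within the scatter), which is within the scatter, with a wide range reflecting the absence of any measured comparison for this change.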

Compound 4, a percentage reported as activity, at one concentration (the size of the read-out at that concentration, not a potency): 41.5%
For compound 4 the middle estimate is 17.5 percentage points below the measured one; the measured number falls inside the stated range.
By their numbers in this assay, from the lowest: compound 3; then compound 2; then compounds 4 and 1 (each within the scatter of the next).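

In this assay, this position turns out to be responsive: 4-chlorophenyl in place of methyl on a saturated chain carbon bound to an amine nitrogen in a ring gives a number 24.3 percentage points higher from compound 3 to compound 4 (beyond the scatter), a step beyond the scatter. The earlier steps shown here exchanged the whole group on the chain carbon bound to the carbonyl carbon, so they could not show that a change at the far end of the piperazine, with the rest of the molecule kept, is enough to move the number. The low value of compound 3 therefore does not hold for the piperazine side chain as a whole: compound 4 gives 41.5% and compound 1 gives 44.9%, two values within the scatter of each other.

The compounds shown offer no evidence on why the number changes with ethyl replaced by 4-chlorobenzyl. Going by these compounds, it remains open whether the step depends on the chlorine, on the aromatic ring or simply on a larger group at this place, and an unsubstituted benzyl or a butyl chain there would begin to separate these.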